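From 4-bromophenyl to pyridin-4-yl on compound 3

The compounds below may be only part of what the source reports. "The series", "measured", "known", "first", "only" and "open" are said of these compounds alone.

In an ADME assay on A549 cells (Homo sapiens) for cytotoxicity, read by resazurin assay, with a stated time of 48 h (a higher number here means that more compound is tolerated, a lower number that less compound is tolerated), compound 3 (`O=C(Nc1ccc(NCc2ccc(Br)cc2)cc1Cl)c1cc(Cl)ccc1O`) gives 40900 nM. Compound 1 (`CCNc1ccc(NC(=O)c2cc(Cl)ccc2O)c(Cl)c1`) gives 30200 nM, within the scatter of compound 3, while compound 2 (`CC1(Nc2ccc(NC(=O)c3cc(Cl)ccc3O)c(Cl)c2)CCCC1`) gives 157000 nM, the highest of the three. Compound 4 (`O=C(Nc1ccc(NCc2ccncc2)cc1Cl)c1cc(Cl)ccc1O`) has pyridin-4-yl in place of 4-bromophenyl on a saturated chain carbon bound to a nitrogen on an aromatic ring. The nearest evidence is the change at that same place, a 1.4-fold higher number from compound 1 to compound 3 (0.13 log units; within the scatter). The larger 5.2-fold higher number from compound 1 to compound 2 (0.72 log units; beyond the scatter) and a 3.8-fold lower number from compound 2 to compound 3 (0.58 log units; beyond the scatter) both involve 1-methylcyclopentyl, which is absent here. Within the data shown here, no measured compound carries pyridin-4-yl, so no step beyond the scatter is expected in this assay. The expected change is a 1.2-fold higher number from compound 3 to compound 4 (0.09 log units; within the scatter). For compound 4 the estimated value is 50000 nM, with an expected range of 20000 nM to 130000 nM.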

Compound 4, half-maximal cytotoxic concentration: 65300 nM
Beside the measured number, compound 4's estimate is 1.3-fold (0.12 log units) below it; measured number inside the range.
By their numbers in this assay, from the lowest: compounds 1, 3 and 4 (each within the scatter of the next, the first and the last beyond it); then compound 2.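

In this assay, replacing the carbon-only ring of 4-bromophenyl with the hetero-atom ring of pyridin-4-yl gives a 1.6-fold higher number from compound 3 to compound 4 (0.20 log units; within the scatter), so this exchange at this place does not clearly shift the tolerated concentration. The steps from the other two groups on that nitrogen do pass the scatter: a 2.4-fold lower number from compound 2 to compound 4 (0.38 log units; beyond the scatter), and a 2.2-fold higher number from compound 1 to compound 4 (0.33 log units; beyond the scatter). No measurement here accounts for these steps. As far as these compounds go, whether a carboxylic acid, a dimethylamino group or a longer chain on the ring at this place would give a step beyond the scatter remains open.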